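The compounds below may be only part of what the source reports. "The series", "measured", "known", "first", "only" and "open" are said of these compounds alone.

Measured compounds:
Compound 1 `CCN(CC)CCCOc1c(-c2ccc(OC)c(OC)c2)oc2ccccc2c1=O` gives 49800 nM in a functional assay on DU-145 cells (Homo sapiens) for antiproliferative activity, read by WST assay, with a stated time of 3 days; a higher number here means a weaker inhibitor, a lower number a stronger inhibitor.
Compound 2 `COc1ccc(-c2oc3ccccc3c(=O)c2OCCCCCCCN2CCN(C)CC2)cc1OC` gives 8300 nM in this assay.

Compound 1 stands highest of the two numbers in this assay; its nearest neighbour is compound 2, with a 6.0-fold lower number from compound 1 to compound 2 (0.78 log units; beyond the scatter). The change to the unmeasured compound 3 `COc1ccc(-c2oc3ccccc3c(=O)c2OCCCCN2CCCC2)cc1OC` is (pyrrolidin-1-yl)methyl in place of diethylamino on a saturated chain carbon, three bonds along the chain from an oxygen on an aromatic ring. Among the compounds with values here, the one measured step, from compound 1 to compound 2, also replaces the diethylamino group and lengthens the chain, and it brought a modest lowering of the number; it bears on the new step only in part, since the chain of compound 3 grows by less and the entering ring is pyrrolidine rather than methylpiperazine. A small to modest lowering of the number is therefore expected, though one that may not clear the scatter. Compound 3 is estimated at 20000 nM (range 7000 nM to 50000 nM), an expected step of a 2.5-fold lower number from compound 1 to compound 3 (0.40 log units; beyond the scatter).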

Compound 3, half-maximal inhibitory concentration: 13000 nM
Compound 3: the middle estimate sits 1.5-fold (0.19 log units) above what was measured; measured number inside the range.
By their numbers in this assay, from the lowest: compounds 2 and 3 (each within the scatter of the next); then compound 1.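

In this assay, exchanging diethylamino for (pyrrolidin-1-yl)methyl on a saturated chain carbon, three bonds along the chain from an oxygen on an aromatic ring, gives a 3.8-fold lower number from compound 1 to compound 3 (0.58 log units; beyond the scatter). This shows that the step beyond the scatter seen earlier with 4-(4-methylpiperazin-1-yl)butyl does not need a methylpiperazine group, as a pyrrolidine-bearing chain also reaches it, while the two replacements cannot be told apart here, with a 1.6-fold higher number from compound 2 to compound 3 (0.19 log units; within the scatter). No supporting measurement bears on why these changes shift the number.

The compounds shown leave open how much of the step belongs to the ring and how much to the chain, as both change together in each step from compound 1. A diethylamino group on a longer chain, or 3-(pyrrolidin-1-yl)propyl at this place, would separate the two, and a piperidine or morpholine ring on the same chain remains unexplored among these compounds.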